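A few compounds are considered here, and "the series" means these few. Any claim that something is new, unique, unknown or untested is made for them only; others in the source may bear on it.

Working notes on the series. The three measured compounds share one core and differ only in the group on the amide-type nitrogen. Compound 1 `CCN(CC)S(=O)(=O)c1ccc(S(=O)(=O)N2CCC[C@@H](C(=O)NC3COC3)C2)cc1` gives 13800 nM in a functional assay on BXPC-3 cells (Homo sapiens) for inhibition, read by MTT assay, with a stated time of 7 days; on this read-out higher numbers stand for weaker inhibition and lower numbers for stronger inhibition. Compound 2 `CCN(CC)S(=O)(=O)c1ccc(S(=O)(=O)N2CCC[C@@H](C(=O)N[C@H]3CC[C@H](OC)CC3)C2)cc1` gives 2000 nM in this assay. Compound 3 `CCN(CC)S(=O)(=O)c1ccc(S(=O)(=O)N2CCC[C@@H](C(=O)N[C@@H]3CCOC3)C2)cc1` gives 2270 nM in this assay. Compound 3 stands second highest of the three numbers: the step to its nearest number is a 1.1-fold higher number from compound 2 to compound 3 (0.05 log units; within the scatter), and the step to its furthest is a 6.1-fold lower number from compound 1 to compound 3 (0.78 log units; beyond the scatter).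

Compound 4 `CCN(CC)S(=O)(=O)c1ccc(S(=O)(=O)N2CCC[C@@H](C(=O)N3CCC(C(F)F)CC3)C2)cc1` is not yet measured. The change from compound 3 is 4-(difluoromethyl)piperidin-1-yl in place of (oxolan-3-yl)amino on a carbonyl carbon. The measured steps bear on it only loosely: a 6.9-fold lower number from compound 1 to compound 2 (0.84 log units; beyond the scatter) and a 6.1-fold lower number from compound 1 to compound 3 (0.78 log units; beyond the scatter) both lower the number when oxetan-3-yl gives way to a larger ring, and a 1.1-fold higher number from compound 2 to compound 3 (0.05 log units; within the scatter) shows that oxolan-3-yl and 4-methoxycyclohexyl cannot be told apart. Within the data shown here, no measured step exchanges an amino group for a piperidin-1-yl group or drops the hydrogen-bond donor, so the change to compound 4 has no direct precedent here. From the compounds shown here alone, the six-membered ring sits on the side of the series that has given the lower numbers, but the loss of the donor is untested, so a small shift within or just beyond the scatter is expected. Compound 4 is estimated at 3500 nM, with a range from 900 nM to 14000 nM, which means an expected step of a 1.5-fold higher number from compound 3 to compound 4 (0.19 log units; within the scatter).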

Compound 4, half-maximal inhibitory concentration: 450 nM
Estimate against measurement, compound 4: 7.8-fold (0.89 log units) above; measured number outside the range, below it.
By their numbers in this assay, from the lowest: compound 4; then compounds 2 and 3 (each within the scatter of the next); then compound 1.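

In this assay, keeping the amide hydrogen proves not to be required at this position: 4-(difluoromethyl)piperidin-1-yl on the carbonyl carbon, which has no such hydrogen, gives a 5.0-fold lower number from compound 3 to compound 4 (0.70 log units; beyond the scatter) and a 4.4-fold lower number from compound 2 to compound 4 (0.65 log units; beyond the scatter), and the widest gap in the series is a 31-fold lower number from compound 1 to compound 4 (1.49 log units; beyond the scatter). Until now the position had separated only oxetan-3-yl from the two larger rings, and those two could not be told apart, with a 1.1-fold higher number from compound 2 to compound 3 (0.05 log units; within the scatter); the new group moves the read-out beyond the scatter of both, making compound 4 the strongest of the four by steps beyond the scatter to every other compound. Nothing at hand accounts for this gain, and the numbers alone do not supply an explanation.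

Open, from the compounds shown here alone, is which part of the exchange carries the step, as the loss of the amide hydrogen, the piperidin-1-yl ring and the difluoromethyl group all enter together in compound 4. An unsubstituted piperidin-1-yl, a 4-methylpiperidin-1-yl or a morpholin-4-yl group on the same carbonyl carbon would separate these contributions, and a 4-(trifluoromethyl)piperidin-1-yl group would test how much the fluorinated substituent matters.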